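Capping the hydroxy group of compound 3

A few compounds are considered here, and "the series" means these few. Any claim that something is new, unique, unknown or untested is made for them only; others in the source may bear on it.

Values in a functional assay on SW-620 cells (Homo sapiens) for cytotoxicity (on this read-out lower numbers stand for stronger inhibition of growth and higher numbers for weaker inhibition of growth), for the measured compounds:
- compound 1 `CSc1ccc(C2=C(c3ccc(F)c(F)c3)C(=O)N3CCCC3C2)cc1`: 200 nM
- compound 2 `COc1ccc(C2=C(c3ccc(SC)cc3)CC3CCCN3C2=O)cc1`: 3000 nM
- compound 3 `CSc1ccc(C2=C(c3ccc(O)cc3)C(=O)N3CCCC3C2)cc1`: > 100000 nM (a limit, not a number)

Compound 3 has no number of its own: what stands for it is the limit of > 100000 nM in this assay, at which 1 of the 3 values shown sits, and nothing more. The change to compound 4 `CSc1ccc(C2=C(c3ccc(OCC4CO4)cc3)C(=O)N3CCCC3C2)cc1` is (oxiran-2-yl)methyl in place of hydrogen on an oxygen on an aromatic ring and turns hydroxy into (oxiran-2-yl)methoxy. The closest guide is an at least 33-fold higher number from compound 2 to compound 3 (1.52 log units; beyond the scatter) for hydrogen in place of methyl on that same oxygen, a large step beyond the scatter. Also large are a 15-fold higher number from compound 1 to compound 2 (1.18 log units; beyond the scatter) and an at least 500-fold higher number from compound 1 to compound 3 (2.69 log units; beyond the scatter) for changes of the whole group at that place. Compound 2, at 3000 nM with a methyl on that oxygen, is the nearest model, although no (oxiran-2-yl)methyl group has been measured, so the range stays wide. A large step to a lower number, meaning stronger inhibition of growth, is expected, estimated as an at least 33-fold lower number from compound 3 to compound 4 (1.52 log units; beyond the scatter) in this assay for now. Compound 4 is therefore estimated at 3000 nM in this assay, with 400 nM to 20000 nM as the expected range.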

Compound 4, concentration for 50% growth inhibition: 90 nM
Beside the measured number, compound 4's estimate is 33-fold (1.52 log units) above it; measured number below the stated range.
By their numbers in this assay, from the lowest: compound 4; then compound 1; then compound 2. At a limit, above all of these: compound 3.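

Putting (oxiran-2-yl)methyl on the oxygen of compound 3 gives an at least 1100-fold lower number from compound 3 to compound 4 (3.04 log units; beyond the scatter) in this assay. That step is only a bound, since the value of compound 3 is a limit and not a number: the limit of > 100000 nM in this assay, at which 1 of the 4 values shown sits.

For the compounds shown here, what the earlier compounds did not show is that capping this oxygen with methyl is not the end of the gain, for adding oxiran-2-yl to that methyl carbon gives a 33-fold lower number from compound 2 to compound 4 (1.52 log units; beyond the scatter). The compounds shown leave open whether the three-membered ring counts as a ring or simply as extra atoms on the chain. A propyl group, or a chain ending in an amine, on the same oxygen would help to separate these two readings.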